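A few compounds are considered here, and "the series" means these few. Any claim that something is new, unique, unknown or untested is made for them only; others in the source may bear on it.

Compound 1 `ClCc1ccccc1Cn1cnc2c(Cl)nc(Cl)nc21` and compound 2 `ClCc1cccc(Cn2cnc3c(Cl)nc(Cl)nc32)c1` share the same atoms joined differently; the difference between their two cores is not broken down here. In a functional assay on NCI-H460 cells (Homo sapiens) for cytotoxicity, read by sulforhodamine B assay, with a stated time of 48 h (a lower number here means a stronger inhibitor of growth, a higher number a weaker inhibitor of growth), compound 1 gives 8710 nM, and compound 2 gives 6310 nM, two numbers that lie within the usual scatter of each other. Compound 3 `Nc1nc(Cl)c2ncn(Cc3ccccc3CCl)c2n1` arises from compound 1 by one change, (amino in place of chloro on an aromatic carbon); in this assay compound 3 gives 37200 nM, so the step is a 4.3-fold higher number from compound 1 to compound 3 (0.63 log units; beyond the scatter). Compound 4 `Nc1nc(Cl)c2ncn(Cc3cccc(CCl)c3)c2n1` arises from compound 2 by the same change, (amino in place of chloro on an aromatic carbon), made at a place described in the same words, so it is the same change in two pairs. Among the measured compounds shown here, because a 4.3-fold higher number from compound 1 to compound 3 (0.63 log units; beyond the scatter) was the outcome in the one pair measured, a similar step is expected for compound 4, namely a 4.3-fold higher number from compound 2 to compound 4 (0.63 log units; beyond the scatter). Compound 4 is therefore estimated at 27000 nM in this assay, most likely between 12000 nM and 60000 nM.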

Compound 4, concentration for total growth inhibition: 15900 nM
Beside the measured number, compound 4's estimate is 1.7-fold (0.23 log units) above it, and the stated range covers the measured number.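

Putting amino in place of chloro on an aromatic carbon again gives a weaker inhibitor of growth in this assay, here a 2.5-fold higher number from compound 2 to compound 4 (0.40 log units; beyond the scatter). The two steps agree in direction, and the gap between their sizes is no larger than repeated measurements would give: the same change on two cores in this assay, a 4.3-fold higher number (0.63 log units; beyond the scatter) from compound 1 to compound 3 and a 2.5-fold higher number (0.40 log units; beyond the scatter) from compound 2 to compound 4, 1.7-fold (0.23 log units) apart, within the scatter of two such steps. So the change carried over from the core of compound 1 to the core of compound 2, but two pairs do not make a rule for the whole series, and they do not explain why the number rises.

The compounds shown leave open what other groups at this aromatic carbon would do, such as a methoxy group or a dimethylamino group. They also leave open whether the step would hold on a third core.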